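Swapping a methoxyphenyl for a diformylphenyl on the aryl arm

The compounds below may be only part of what the source reports. "The series", "measured", "known", "first", "only" and "open" are said of these compounds alone.

The shared core of compound 1 `CN(C)CCn1c(=O)c(=Cc2ccc(F)c(F)c2)s/c1=C1\C(=O)Nc2cc(F)ccc21` and compound 2 `COc1ccc(C=c2s/c(=C3\C(=O)Nc4cc(F)ccc43)n(CCN(C)C)c2=O)cc1` carries a varied aryl group on a double-bonded chain carbon bound to an aromatic carbon. Among the measured compounds shown here, in a functional assay on HT-29 cells (Homo sapiens) for inhibition, read by MTT assay, with a stated time of 72 h (a higher number here means a weaker inhibitor, a lower number a stronger inhibitor), compound 1 gives 12100 nM, and compound 2 gives 2300 nM, the lowest of the two numbers so far; the single step between them, a 5.3-fold lower number from compound 1 to compound 2 (0.72 log units; beyond the scatter), sets it apart from compound 1.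

Compound 3 `CN(C)CCn1c(=O)c(=Cc2ccc(C=O)c(C=O)c2)s/c1=C1\C(=O)Nc2cc(F)ccc21` is the next move. Relative to compound 2 it shows (3,4-diformylphenyl in place of 4-methoxyphenyl on a double-bonded chain carbon bound to an aromatic carbon). For the measured compounds named here, only one measured step touches this position, a 5.3-fold lower number from compound 1 to compound 2 (0.72 log units; beyond the scatter), and it favoured the 4-methoxyphenyl now being removed. Compound 3 instead takes up a 3,4-diformylphenyl, a pattern nearer in name to the 3,4-difluorophenyl of compound 1 than to the group on compound 2. Going by the values given here, no formyl-bearing compound has been measured in this assay, so the direction rests on that single comparison. A step toward a higher number is therefore expected, a 3.5-fold higher number from compound 2 to compound 3 (0.54 log units; beyond the scatter), in this assay. Compound 3 is estimated at 8000 nM in this assay, with a range from 2000 nM to 30000 nM.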

Compound 3, half-maximal inhibitory concentration: 1360 nM
The estimate for compound 3 lay 5.9-fold (0.77 log units) above the measured number, and the stated range ends above it.
By their numbers in this assay, from the lowest: compounds 3 and 2 (each within the scatter of the next); then compound 1.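

Among the compounds shown here, at this position, on a double-bonded chain carbon bound to an aromatic carbon, the 4-methoxyphenyl is no longer the only group that stands apart from the 3,4-difluorophenyl of compound 1 (an 8.9-fold lower number from compound 1 to compound 3 (0.95 log units; beyond the scatter)), so the earlier separation in this assay is now seen with two different replacements. The change from 4-methoxyphenyl to 3,4-diformylphenyl (a 1.7-fold lower number from compound 2 to compound 3 (0.23 log units; within the scatter)) lies within the scatter, so compound 2 and compound 3 cannot be ordered, and the two groups read alike here even though one has a single ring substituent named and the other has two, which also means that the 3,4-diformylphenyl of compound 3 does not go with the higher number of compound 1. Nothing available explains why these aryl groups read as they do.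

Going by these compounds, it remains open whether compound 3 needs both formyl groups, or whether a phenyl carrying one formyl group, a carboxylic acid or an aminomethyl group at this position would read the same way. Also open, on these data alone, is whether a plain phenyl, with no added group, would fall with compound 1 or with compound 2 and compound 3 in this assay.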